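A few compounds are considered here, and "the series" means these few. Any claim that something is new, unique, unknown or untested is made for them only; others in the source may bear on it.

Compound 1 `c1cn2cc(-c3ccsc3)nc(-c3ccc4ncn(C5CCCCC5)c4c3)c2n1` and compound 2 `c1csc(-c2cn3ccnc3c(-c3ccc4ncn(C5CCCCC5)c4c3)n2)c1` share one core and differ only in the thiophene. In a functional assay on OVCAR-8 cells (Homo sapiens) for inhibition, read by sulforhodamine B assay, with a stated time of 48 h, tested at 10 uM (on this read-out higher numbers stand for more inhibition at the one concentration tested (going by the name of the read-out) and lower numbers for less inhibition), compound 1 gives 12.1%, and in this assay compound 2 gives 9.34%; the step of a number 2.8 percentage points lower from compound 1 to compound 2 (within the scatter) lies within the scatter, so compound 2 simply holds the lower of the two numbers, with compound 1 the nearest to it. Compound 3 `FC(F)(F)c1cccc(-c2cn3ccnc3c(-c3ccc4ncn(C5CCCCC5)c4c3)n2)c1` is the next to be measured. It differs from compound 2 by 3-(trifluoromethyl)phenyl in place of thiophen-2-yl on an aromatic carbon. For the measured compounds named here, no measured step bears directly on this change: the only known step, a number 2.8 percentage points lower from compound 1 to compound 2 (within the scatter), concerns just the point of attachment of the thiophene, and no measured pair trades a five-membered aromatic ring with one hetero atom for a six-membered aromatic ring of carbon only. Since both measured compounds show small inhibition, compound 3 is expected to remain in that region, with a step of a number 5.7 percentage points higher from compound 2 to compound 3 (within the scatter) not beyond the scatter. The estimate for compound 3 is 15%, with a range of 0% to 40%.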

Compound 3, a percentage reported as inhibition, at one concentration (the size of the read-out at that concentration, not a potency): 10.1%
The estimate for compound 3 lay 4.9 percentage points above the measured number; measured number inside the range.
By their numbers in this assay, from the lowest: compounds 2, 3 and 1 (each within the scatter of the next).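

In this assay, putting the larger 3-(trifluoromethyl)phenyl on this aromatic carbon gives a number 0.8 percentage points higher from compound 2 to compound 3 (within the scatter) when it replaces thiophen-2-yl and a number 2 percentage points lower from compound 1 to compound 3 (within the scatter) when it replaces thiophen-3-yl. At this position, next to the ring nitrogen, a change from a five-membered aromatic ring with 1 hetero atom to a six-membered aromatic ring of carbon only therefore leaves all three compounds within the scatter of one another, at small inhibition at the one concentration tested. No measurement at hand offers any explanation of this result.

The compounds shown leave open whether an amine or a carboxylic acid on this carbon would give a number beyond the scatter. They also leave open how a plain phenyl would compare with 3-(trifluoromethyl)phenyl.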